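Adding a chloro group to compound 3

The compounds below may be only part of what the source reports. "The series", "measured", "known", "first", "only" and "open" are said of these compounds alone.

Compound 1 `COc1cccc2ccc(Nc3cc(Cl)ccn3)nc12`: 11900 nM
Compound 2 `Oc1ccc(Cl)c2ccc(Nc3ccccn3)nc12`: 1290 nM
Compound 3 `Oc1cccc2ccc(Oc3ccccn3)nc12`: > 30000 nM

All three compounds were tested in a functional assay on PC-3 cells (Homo sapiens) for antiproliferative activity, read by MTT assay, with a stated time of 96 h; a lower number here means a stronger inhibitor of growth, a higher number a weaker inhibitor of growth. Compound 3 gives > 30000 nM, which is a limit of the assay and not a number (the limit of > 30000 nM in this assay, at which 1 of the 3 values shown sits). Compound 4 `Oc1ccc(Cl)c2ccc(Oc3ccccn3)nc12` differs from compound 3 in one place: chloro in place of hydrogen on an aromatic carbon, para to a hydroxy group. Among the compounds with values here, no measured pair shows this change alone. Compound 2 also carries a chloro group and gives 1290 nM, so a clear gain in growth inhibition is expected in this assay. The expected change is an at least 4.2-fold lower number from compound 3 to compound 4 (0.63 log units; beyond the scatter), a step beyond the scatter. For compound 4 the estimated value is 7000 nM, with an expected range of 1800 nM to 28000 nM.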

Compound 4, concentration for 50% growth inhibition: > 30000 nM
Compound 4 gave a limit, no number (the forecaster's own chance of this, stated with the estimate: 25%); at least 4.2-fold (0.63 log units) between middle value and limit.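

Within the data shown here, compound 3 and compound 4 both give a limit and not a number, so no step between them can be read: the limit of > 30000 nM in this assay, at which 2 of the 4 values shown sit. On these data alone, whether chloro in place of hydrogen changes growth inhibition in this pair stays open.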